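Trifluoromethyl to isopropyl: expected shift in distribution

The source may hold more compounds than are shown below. What is called first, only, known or untested is meant among the compounds shown, and "the series" means these compounds.

In a physicochemical assay for lipophilicity, using the shake flask method, in phosphate buffer, measured as octanol-water partition, with a stated time of 24 h, at pH 7.4, tested at 100 uM (a higher number here means a more lipophilic compound, a lower number a more polar compound), compound 1 `Cc1cccc(C)c1-c1cccc(COc2ccc(S(=O)(=O)CC(=O)O)cc2)c1` gives 2.49. For the measured compounds named here, compound 2 `O=C(O)CS(=O)(=O)c1ccc(OCc2cccc(-c3ccccc3C(F)(F)F)c2)cc1` gives 2.95, the higher of the two measured numbers, and compound 1 is its only neighbour.

The next compound is compound 3 `CC(C)c1ccccc1-c1cccc(COc2ccc(S(=O)(=O)CC(=O)O)cc2)c1`, which carries isopropyl in place of trifluoromethyl on an aromatic carbon, ortho to a large group: isopropyl in place of trifluoromethyl on an aromatic carbon. The same difference reads 2-(trifluoromethyl)phenyl to 2-isopropylphenyl.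

Going by the values given here, only one measured step bears on this change: a number 0.46 log units higher from compound 1 to compound 2 (beyond the scatter), where 2-(trifluoromethyl)phenyl stands in place of 2,6-dimethylphenyl. That step is modest, and it shows that a change in this aryl group can move the number beyond the scatter. Among the compounds with values here, it is an indirect guide only, as no measured compound carries isopropyl.

A small rise in this assay is expected, one not clearly beyond the scatter, and the estimated change is a number 0.15 log units higher from compound 2 to compound 3 (within the scatter). The uncertainty is wide enough to include a larger rise or a small fall. For compound 3, the estimate is 3.1, with an expected range from 2.7 to 3.5.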

Compound 3, distribution coefficient: 3.18
Compound 3: the middle estimate sits 0.08 log units below what was measured; the range from low to high includes it.
By their numbers in this assay, from the lowest: compound 1; then compounds 2 and 3 (each within the scatter of the next).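

Notes on this position: in this assay, isopropyl in place of trifluoromethyl, on an aromatic carbon ortho to a large group, gives a number 0.23 log units higher from compound 2 to compound 3 (within the scatter), so this exchange of an all-carbon group for a fluorinated one leaves compound 2 and compound 3 unresolved in this read-out. Against the 2,6-dimethylphenyl group, 2-isopropylphenyl gives a number 0.69 log units higher from compound 1 to compound 3 (beyond the scatter), so compound 3 joins compound 2 as a second example standing clear of compound 1, and among these three compounds the only separation beyond the scatter lies between compound 1 and the other two. No supporting measurement accompanies these numbers, and the reason for this grouping remains unexplained.

The compounds shown leave open whether a group carrying a heteroatom at this position, such as an amine, a methoxy group or a nitrile, would stay close to compound 2 and compound 3 or fall towards compound 1. They also leave open how a larger or longer alkyl group, such as tert-butyl or an n-butyl chain, would read in this assay when placed on the same aromatic carbon.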